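The source may hold more compounds than are shown below. What is called first, only, known or untested is meant among the compounds shown, and "the series" means these compounds.

Working notes on the series. Of the compounds shown here, two have numbers so far. In an ADME assay on liver for metabolic stability, with Liver microsome (Homo sapiens) as the target, using microsomes (a higher number here means faster removal of the compound, a lower number slower removal), compound 1 `O=C(NC[C@@H]1CCCO1)c1cn(Cc2ccc(-n3cccn3)cc2)c2cccnc12` gives 133 mL/min/kg, the highest of the two numbers shown; the nearest is compound 2 `O=C(N[C@H]1CCCC[C@@H]1O)c1nn(Cc2ccc(-n3cccn3)cc2)c2ccccc12`, which in this assay gives 38 mL/min/kg, and the gap between those two values lies beyond the scatter. For the measured compounds named here, compound 1 and compound 2 differ in more than one place, so the two values are only noted side by side and no single step is drawn between them.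

Compound 3 `O=C(N[C@H]1CCCC[C@@H]1O)c1cn(Cc2ccc(-n3cccn3)cc2)c2cccnc12` has not been measured. It differs from compound 1 in one place: 2-hydroxycyclohexyl in place of (oxolan-2-yl)methyl on an amide-type nitrogen. The entering group is the same 2-hydroxycyclohexyl that compound 2 carries on its amide-type nitrogen, while the shared core of compound 1 is kept.

For compound 3 a lower number than compound 1 is expected in this assay, with the step from compound 1 to compound 3 estimated at a 2.2-fold lower number from compound 1 to compound 3 (0.35 log units; beyond the scatter), a change of moderate size that may sit near the edge of the scatter. The expected value for compound 3 is 60 mL/min/kg, with an estimated range from 30 mL/min/kg to 120 mL/min/kg.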

Compound 3, clearance: 59 mL/min/kg
Estimate against measurement, compound 3: 1.0-fold (0.01 log units) above; the range from low to high includes it.
By their numbers in this assay, from the lowest: compounds 2 and 3 (each within the scatter of the next); then compound 1.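

For the compounds shown here, on the amide-type nitrogen, with the core of compound 1 kept, 2-hydroxycyclohexyl in place of (oxolan-2-yl)methyl gives a 2.3-fold lower number from compound 1 to compound 3 (0.35 log units; beyond the scatter) in this assay and provides the first single-place reading, showing that the group at this position can shift the read-out beyond the scatter, though only modestly. The change has several parts: the five-membered ring containing oxygen gives way to a six-membered ring of carbon only, a hydrogen-bond donor enters, and the number of defined stereocentres rises, so this single step cannot separate these features. Nothing measured here bears on what lies behind the step, which remains an observation on this one pair.

The compounds shown leave open whether the hydroxyl group matters or the carbocyclic ring alone would give a similar number, a question that plain cyclohexyl on the same nitrogen would address. Also open, from the compounds shown here alone, are the effect of the other stereoisomers of 2-hydroxycyclohexyl and whether an amine-bearing group such as piperidin-4-yl would fit the same trend.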